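This account rests on a few compounds, and the source may have more. Where it says the series, first, only, none or still open, it means among the compounds named here.

The measured compounds:
Compound 1, `CSc1nc2c(C)nsc2n1[C@H]1C[C@H](O)[C@@H](CO)O1`: in a functional assay on HFF cells (Homo sapiens) for inhibition (a lower number here means a stronger inhibitor, a higher number a weaker inhibitor), compound 1 gives > 100000 nM, which is a limit of the assay and not a number.
Compound 2, `Cc1nsc2c1ncn2[C@@H]1O[C@H](CO)[C@@H](O)[C@H]1O`: in this assay compound 2 gives 150000 nM.

Among the measured compounds shown here, compound 2 holds the only true number in this pair; the other value recorded is a limit. Compound 1 sits at the limit of > 100000 nM in this assay, at which 1 of the 2 values shown sits, which is a limit of the assay rather than a number. Compound 3, `CSc1nc2c(C)nsc2n1[C@@H]1O[C@H](CO)[C@@H](O)[C@H]1O`, has not yet been measured in this assay. It differs from compound 2 in one place: methylsulfanyl in place of hydrogen on an aromatic carbon. For the measured compounds named here, no step between measured compounds is available to gauge what this change does, so the expectation rests on compound 2 alone, which is a weak inhibitor in this assay at 150000 nM. The step of no change at the digits printed from compound 2 to compound 3 (within the scatter) is expected to be no larger than the usual scatter, in either direction. The value of compound 3 in this assay is estimated at 150000 nM, with a range from 40000 nM to 600000 nM, and a fair chance that the assay returns only a limit.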

Compound 3, half-maximal inhibitory concentration: > 100000 nM
Compound 3: a limit, no number (the forecaster's own chance of this, stated with the estimate: 60%); the middle value does not contradict the limit.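

For compound 3, the result in this assay is a limit and not a number: the limit of > 100000 nM in this assay, at which 2 of the 3 values shown sit. Neither the step from compound 2 to compound 3 nor the step from compound 1 to compound 3 can be read. The compounds shown leave open whether methylsulfanyl in place of hydrogen on an aromatic carbon, or hydroxy in place of hydrogen on a saturated ring carbon, changes the result at all.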